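Nitrile for trifluoromethyl on the aryl ether of compound 1

A few compounds are considered here, and "the series" means these few. Any claim that something is new, unique, unknown or untested is made for them only; others in the source may bear on it.

Compound 1 `CC(CCNC(=O)c1c(Cl)cncc1Cl)N1CCC(C(Oc2cccc(C(F)(F)F)c2)c2ccc(C(F)(F)F)cc2)CC1` was examined in an ADME assay on PBMC cells (Homo sapiens) for cytotoxicity (a lower number here means that less compound is tolerated, a higher number that more compound is tolerated), where compound 1 gives 7000 nM. Two further compounds were run in this assay. Compound 2 `CCO/N=C(/c1ccc(Br)cc1)C1CCN(C(CC)CCNC(=O)c2c(C)cc[n+]([O-])c2C)CC1` gives > 177000 nM, which is a limit of the assay rather than a number. Compound 3 `CCO/N=C(/c1ccc(Br)cc1)C1CCN(C(C)CCN(C)C(=O)c2c(C)cc[n+]([O-])c2C)CC1` gives > 182000 nM, again a limit and not a number. Among the three values shown, compound 1 therefore holds the only measured number. The other two values are limits only: the limit of > 177000 nM in this assay, at which 1 of the 3 values shown sits, and (the limit of > 182000 nM in this assay, at which 1 of the 3 values shown sits).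

Compound 4 `CC(CCNC(=O)c1c(Cl)cncc1Cl)N1CCC(C(Oc2ccccc2C#N)c2ccc(C(F)(F)F)cc2)CC1` has not yet been measured in this assay. It differs from compound 1 in a single place: 2-cyanophenyl in place of 3-(trifluoromethyl)phenyl on an oxygen on a saturated carbon. Among the measured compounds shown here, no step between two measured compounds that differ in only one place is available here, so the size of the effect of this change in this assay can only be estimated from the structures themselves. The author expects a small shift toward a more tolerated compound, not clearly beyond the scatter of repeated measurements, and states this expectation as the step of a 1.6-fold higher number from compound 1 to compound 4 (0.20 log units; within the scatter). For compound 4 the estimated half-maximal cytotoxic concentration in this assay is 11000 nM. This estimate for compound 4 is expected to lie between 4000 nM and 35000 nM.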

Compound 4, half-maximal cytotoxic concentration: 17000 nM
Beside the measured number, compound 4's estimate is 1.5-fold (0.19 log units) below it; measured number inside the range.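

In this assay, among the compounds shown here, 2-cyanophenyl in place of 3-(trifluoromethyl)phenyl on an oxygen on a saturated carbon gives a 2.4-fold higher number from compound 1 to compound 4 (0.39 log units; beyond the scatter), the first step that can be read at this position, since compound 2 and compound 3 each differ from compound 1 in more than one place. The step is modest, but it shows that the read-out responds to the aryl group on this oxygen while the rest of compound 1 stays fixed, with more of compound 4 tolerated than of compound 1. None of the information shown bears on what lies behind this step.

The change replaces the trifluoromethyl group with a nitrile and also alters the group's place on the ring, so the compounds shown cannot separate these two parts of the step. On these data alone, it also remains open how a phenyl ring carrying an amine or a carboxylic acid would read on this oxygen, and whether the same exchange would give a step of similar size on a core other than that of compound 1.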